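Changing the aryl group on the ring nitrogen of compound 2

The compounds below may be only part of what the source reports. "The series", "measured", "known", "first", "only" and "open" are said of these compounds alone.

Measured so far:
compound 1, `Nc1scc(CN2CCN(c3ccc(Cl)cc3F)CC2)c1C(=O)c1ccc(Cl)cc1`, -57%
compound 2, `Nc1scc(CN2CCN(c3ccccc3C(F)(F)F)CC2)c1C(=O)c1ccc(Cl)cc1`, -39%
compound 3, `Nc1scc(CN2CCN(c3c(F)cccc3F)CC2)c1C(=O)c1cccc(C(F)(F)F)c1`, 1.3%

In a functional assay on CHO cells with adenosine receptor A1 (Homo sapiens) as the target, read by cAMP accumulation and immunoassay, with a stated time of 6 min, tested at 1 uM (a lower number here means a stronger effect, a higher number a weaker effect of the compound at the concentration tested), compound 2 stands second highest of the three, with compound 1 lower and compound 3 higher. Among the measured compounds shown here, the only single-place step measured is a number 18 percentage points higher from compound 1 to compound 2 (beyond the scatter). Compound 4, `Nc1scc(CN2CCN(c3ccc(F)c(F)c3)CC2)c1C(=O)c1ccc(Cl)cc1`, differs from compound 2 as follows: 3,4-difluorophenyl in place of 2-(trifluoromethyl)phenyl on an amine nitrogen in a ring. Compound 3 differs in two places and only shows that a difluorophenyl can go with a value near zero. For the measured compounds named here, the one relevant step is modest, so no step beyond the scatter is expected in this assay for compound 4; the expected step is a number 6 percentage points lower from compound 2 to compound 4 (within the scatter). Compound 4 is therefore estimated at -45%, within -72% to -18%.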

Compound 4, a percentage reported as activity, at one concentration (the size of the read-out at that concentration, not a potency): -78%
Beside the measured number, compound 4's estimate is 33 percentage points above it; measured number outside the range, below it.
By their numbers in this assay, from the lowest: compound 4; then compound 1; then compound 2; then compound 3.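

In this assay, among the compounds shown here, the group on the ring nitrogen turns out to matter more than the one earlier step showed. There is a number 39 percentage points lower from compound 2 to compound 4 (beyond the scatter) with 3,4-difluorophenyl replacing 2-(trifluoromethyl)phenyl, and a number 21 percentage points lower from compound 1 to compound 4 (beyond the scatter) with it replacing 4-chloro-2-fluorophenyl, so 3,4-difluorophenyl gives the lowest number of these three aryl groups on the same core. No measurement shown accounts for this. From the compounds shown here alone, it remains open whether an unsubstituted phenyl, a methoxyphenyl or a pyridine ring at this nitrogen would give a number as low.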